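Swapping 4-fluorophenyl for 3-chlorophenyl at the assay's limit

The source may hold more compounds than are shown below. What is called first, only, known or untested is meant among the compounds shown, and "the series" means these compounds.

In a functional assay on OVCAR-3 cells (Homo sapiens) for antiproliferative activity, read by MTT assay, with a stated time of 24 h (on this read-out higher numbers stand for weaker inhibition and lower numbers for stronger inhibition), compound 3 `O=c1[nH]cc(S(=O)(=O)Nc2cccc(-c3cn(-c4ccc(F)cc4)nn3)c2)c(=O)[nH]1` gives > 20000 nM, which is a limit of the assay and not a number. Compound 2 `O=c1[nH]cc(S(=O)(=O)Nc2cccc(-c3cn(-c4cccc(F)c4)nn3)c2)c(=O)[nH]1` gives > 20000 nM, and this too is a limit. Compound 1 `Cc1cccc(-n2cc(-c3cccc(NS(=O)(=O)c4c[nH]c(=O)[nH]c4=O)c3)nn2)c1` gives a true reading of 4080 nM.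

Compound 4 `O=c1[nH]cc(S(=O)(=O)Nc2cccc(-c3cn(-c4cccc(Cl)c4)nn3)c2)c(=O)[nH]1` carries 3-chlorophenyl in place of the 4-fluorophenyl of compound 3, on an aromatic nitrogen (3-chlorophenyl in place of 4-fluorophenyl on an aromatic nitrogen).

Within the data shown here, three measured steps bear on this change. Fluoro in place of methyl gave an at least 4.9-fold higher number from compound 1 to compound 2 (0.69 log units; beyond the scatter), and 4-fluorophenyl in place of 3-methylphenyl gave an at least 4.9-fold higher number from compound 1 to compound 3 (0.69 log units; beyond the scatter). Among the measured compounds shown here, both lie beyond the scatter, and both start from the only compound with a readable number. Between the two fluorophenyl compounds, the limits leave a step that the two limits leave unreadable from compound 2 to compound 3.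

The name 3-chlorophenyl recalls both the 3-methylphenyl of compound 1 and the 3-fluorophenyl of compound 2, yet those two compounds part by the first step above, so the guidance is mixed. A modest move towards stronger inhibition seems likely, though the reading may well stay at the limit.

The expected step is an at least 1.8-fold lower number from compound 3 to compound 4 (0.25 log units; that floor lies within the scatter). For compound 4 the estimated value is 11000 nM, within an expected range from 3500 nM to 35000 nM.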

Compound 4, half-maximal inhibitory concentration: 3410 nM
Beside the measured number, compound 4's estimate is 3.2-fold (0.51 log units) above it; the whole stated range lies above it.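

In this assay, 3-chlorophenyl on the aromatic nitrogen gives a true reading where both fluorophenyl groups gave none: the swap for 4-fluorophenyl gives an at least 5.8-fold lower number from compound 3 to compound 4 (0.76 log units; beyond the scatter), and chloro in place of fluoro on the aromatic carbon gives an at least 5.8-fold lower number from compound 2 to compound 4 (0.76 log units; beyond the scatter). The earlier compounds left open whether any halogen on this ring would lose the reading, and compound 4 shows that, among the groups shown, this loss is confined to the two fluoro compounds, while chloro in place of methyl gives a 1.2-fold lower number from compound 1 to compound 4 (0.08 log units; within the scatter), so 3-chlorophenyl and 3-methylphenyl cannot be told apart here. The true size of the two steps from the fluoro compounds stays unknown, and they are only floors, because compound 2 and compound 3 each give a limit and not a number: the limit of > 20000 nM in this assay, at which 2 of the 4 values shown sit.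

Compound 3 and compound 4 differ in both the halogen and its place on the ring, so 4-chlorophenyl would be needed to separate those two changes. From the compounds shown here alone, it also remains open whether 3-bromophenyl or 3-methoxyphenyl would read like compound 4 or go further towards stronger inhibition.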